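Swapping a carbonyl substituent to reach a carbamoyl

The source may hold more compounds than are shown below. What is called first, only, known or untested is meant among the compounds shown, and "the series" means these compounds.

The compounds share one core and differ only in the group that hangs from a carbonyl carbon attached to an amide-type nitrogen. Compound 1 `COc1cc(-c2nn(-c3cccc(NC(=O)Nc4cc(C(F)(F)F)cc(C(F)(F)F)c4)c3)cc2-c2ccncc2)ccc1Cl` was tested in a functional assay on SK-MEL-28 cells (Homo sapiens) for inhibition, read by sulforhodamine B assay, with a stated time of 48 h (on this read-out lower numbers stand for higher toxicity in this test and higher numbers for lower toxicity in this test), and gave 3380 nM. Compound 2 `COc1cc(-c2nn(-c3cccc(NC(=O)c4cccc(C(F)(F)F)c4)c3)cc2-c2ccncc2)ccc1Cl` was tested in the same way, and for compound 2 this assay returns > 50000 nM, which is a limit of the test rather than a number. Of the two values shown, compound 2 alone sits at such a limit (the limit of > 50000 nM in this assay, at which 1 of the 2 values shown sits). Compound 3 `COc1cc(-c2nn(-c3cccc(NC(=O)Nc4ccc(Cl)c(Cl)c4)c3)cc2-c2ccncc2)ccc1Cl` has not yet been measured. It differs from compound 2 by (3,4-dichlorophenyl)amino in place of 3-(trifluoromethyl)phenyl on a carbonyl carbon; cut one bond further out, the change reads (3-(trifluoromethyl)phenyl)carbonyl to (3,4-dichlorophenyl)carbamoyl, which brings compound 3 closer in build to compound 1. Going by the values given here, no step between measured compounds exists for a direct comparison. Because compound 1 gives 3380 nM, the expected step is toward higher toxicity in this assay, namely an at least 12-fold lower number from compound 2 to compound 3 (1.09 log units; beyond the scatter). Compound 3 is accordingly estimated at 4000 nM, within a range from 1500 nM to 15000 nM.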

Compound 3, concentration lethal to 50% of the cells: > 50000 nM
Compound 3: only a limit was reported (the forecaster's own chance of this, stated with the estimate: 25%); middle value at least 12-fold (1.09 log units) from the limit.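

In this assay, compound 2 and compound 3 both stop at a limit of the test rather than at a number, so no step can be read between them: the limit of > 50000 nM in this assay, at which 2 of the 3 values shown sit.

The compounds shown leave open how far apart compound 2 and compound 3 really lie, and which of the two, if either, is the more toxic.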